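Swapping a dimethylpiperazine for a fused bicyclic amine

The source may hold more compounds than are shown below. What is called first, only, known or untested is meant among the compounds shown, and "the series" means these compounds.

Among the measured compounds shown here, compound 1 `C[C@@H]1CN(c2cccc3c2C[C@H](CN(C)[C@H]2CCCc4cccnc42)NC3)C[C@H](C)N1` gives 61 nM in a functional assay on CCRF-CEM cells for antagonist activity at C-X-C chemokine receptor type 4 (Homo sapiens), read by calcium flux, with stated times of 25 min and 90 s (a higher number here means a weaker inhibitor, a lower number a stronger inhibitor), the lowest of the two numbers measured so far. Compound 2 `CN(C[C@@H]1Cc2c(cccc2N2CCNCC2)CN1)[C@H]1CCCc2cccnc21` gives 313 nM in this assay, a weaker result that lies beyond the usual scatter. Compound 3 `CN(C[C@H]1Cc2c(cccc2N2CCN3CCC[C@@H]3C2)CN1)[C@H]1CCCc2cccnc21` has not been measured yet. It differs from compound 1 by a group of 9 heavy atoms (7 carbon, 2 nitrogen; one five-membered non-aromatic ring with 1 hetero atom, one six-membered non-aromatic ring with 2 hetero atoms) in place of a group of 8 heavy atoms (6 carbon, 2 nitrogen; one six-membered non-aromatic ring with 2 hetero atoms), on an aromatic carbon. For the measured compounds named here, no measured pair shows this kind of change, so only a small loss is expected, since the group that leaves belongs to compound 1 with 61 nM. The step of a 1.8-fold higher number from compound 1 to compound 3 (0.26 log units; within the scatter) is expected to be modest. Compound 3 is therefore estimated at 110 nM, within 40 nM to 350 nM.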

Compound 3, half-maximal inhibitory concentration: 3.59 nM
Compound 3: middle estimate off by 31-fold (1.49 log units), on the high side, outside the stated range (below it).
By their numbers in this assay, from the lowest: compound 3; then compound 1; then compound 2.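

The group on this aromatic carbon can strongly shift the result: the two-ring group in place of 3,5-dimethylpiperazin-1-yl gives a 17-fold lower number from compound 1 to compound 3 (1.23 log units; beyond the scatter) in this assay for this single change. The entering group has no hydrogen-bond donor and the leaving group has one, but this one step cannot separate that difference from the added five-membered ring. Nothing measured here explains the gain. On these data alone, whether the second ring itself matters stays open; a 4-methylpiperazin-1-yl or morpholin-4-yl group on this carbon would help to tell.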